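Swapping fluoro for methoxy on a 4-fluorophenyl group

The compounds below may be only part of what the source reports. "The series", "measured", "known", "first", "only" and "open" are said of these compounds alone.

Compound 1 `CCNc1nccc2ncc(-c3cnn(C)c3)cc12`: > 50000 nM (a limit)
Compound 2 `Cn1cc(-c2cnc3ccnc(NCc4ccc(F)cc4)c3c2)cn1`: 9200 nM

Both compounds were tested in a functional assay on HeLa cells (Homo sapiens) for antiproliferative activity, read by MTT assay, with a stated time of 48 h; a higher number here means a weaker inhibitor, a lower number a stronger inhibitor. Compound 1 reached only > 50000 nM, which is a limit of the assay and not a number. Among the compounds with values here, that leaves compound 2, at 9200 nM, as the only true number so far, so it cannot yet be ranked against any other measured value.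

Compound 3 `COc1ccc(CNc2nccc3ncc(-c4cnn(C)c4)cc23)cc1` keeps everything in compound 2 except one group: methoxy in place of fluoro on an aromatic carbon. This places methoxy in place of fluoro on an aromatic carbon, para to a large group, turning 4-fluorophenyl into 4-methoxyphenyl.

Within the data shown here, the only measured step, an at least 5.4-fold lower number from compound 1 to compound 2 (0.73 log units; beyond the scatter), put 4-fluorophenyl in place of methyl. It shows nothing about swapping the fluoro group itself, so from it no step beyond the scatter is expected in this assay, in either direction. The expected change is a 1.1-fold higher number from compound 2 to compound 3 (0.04 log units; within the scatter). The estimate for compound 3 is 10000 nM, with an expected range from 3500 nM to 30000 nM.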

Compound 3, half-maximal inhibitory concentration: 42200 nM
Estimate against measurement, compound 3: 4.2-fold (0.63 log units) below; the measured number lies above the stated range.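

In this assay, methoxy in place of fluoro on an aromatic carbon, para to a large group, brings a modest step: a 4.6-fold higher number from compound 2 to compound 3 (0.66 log units; beyond the scatter). The earlier step, an at least 5.4-fold lower number from compound 1 to compound 2 (0.73 log units; beyond the scatter), showed only that 4-fluorophenyl in place of methyl goes with a lower number, whereas this one shows that the group carried on that phenyl ring also counts, since 4-methoxyphenyl gives back much of that ground. The remaining step, an at least 1.1-fold lower number from compound 1 to compound 3 (0.07 log units; that floor lies within the scatter), has a floor within the scatter and cannot be read. Compound 1 stands at a limit of the assay, which is not a number: the limit of > 50000 nM in this assay, at which 1 of the 3 values shown sits.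

As far as these compounds go, with only fluoro and methoxy compared at this position, it stays open whether hydrogen, chloro, hydroxy or an amine in the same place would give a number closer to that of compound 2 or of compound 3. Nothing measured here explains the step, and the compounds shown do not tell whether the same swap would have a similar effect with a longer chain joining the phenyl ring to the nitrogen.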